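This account rests on a few compounds, and the source may have more. Where it says the series, first, only, none or still open, it means among the compounds named here.

Measured so far:
- compound 1 `COC(=O)c1nc(C)n(-c2ccccc2)n1`: in a functional assay on Jurkat cells (Homo sapiens) for inhibition, read by MTT assay, with a stated time of 72 h (on this read-out higher numbers stand for weaker inhibition of growth and lower numbers for stronger inhibition of growth), compound 1 gives > 100000 nM, which is a limit of the assay, not a number.
- compound 2 `COC(=O)c1nc(C)n(-c2cccc(Br)c2)n1`: compound 2 gives > 100000 nM, again a limit of the assay.
- compound 3 `COC(=O)c1nc(C)n(-c2ccc(C(F)(F)F)cc2)n1`: compound 3 gives 9100 nM.

Among the three values compound 3 thus holds the only real number; the other two sit at the limit of > 100000 nM in this assay, at which 2 of the 3 values shown sit. Compound 4 `COC(=O)c1nc(C)n(-c2ccc(OC)cc2)n1` differs from compound 3 in one place: methoxy in place of trifluoromethyl on an aromatic carbon. Among the compounds with values here, two measured steps bear on this. The step of an at least 10-fold lower number from compound 1 to compound 3 (1.04 log units; beyond the scatter) shows that placing trifluoromethyl on the unsubstituted ring of compound 1 gave a large gain. The step that the two limits leave unreadable from compound 1 to compound 2 cannot be read, as both ends are limits. Taking the trifluoromethyl away again would therefore be expected to lose much of that gain, and the methoxy that enters has no measured counterpart here. The expected step is a 6.6-fold higher number from compound 3 to compound 4 (0.82 log units; beyond the scatter), toward a higher number, with a real chance of another limit. The estimate for compound 4 is 60000 nM, in the range 15000 nM to 200000 nM.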

Compound 4, concentration for 50% growth inhibition: > 100000 nM
Compound 4 ended at the assay's limit (the forecaster's own chance of this, stated with the estimate: 50%); middle value at least 1.6-fold (0.22 log units) away from the limit.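

In this assay, methoxy in place of trifluoromethyl on an aromatic carbon, para to a large group, gives an at least 10-fold higher number from compound 3 to compound 4 (1.04 log units; beyond the scatter). The gain seen in compound 3 therefore does not appear with every group placed here, as compound 4 gives > 100000 nM, which is a limit of the assay, not a number. The steps from compound 1 to compound 2 and to compound 4 cannot be read, as both ends are limits, and trifluoromethyl remains the only group shown with a real number: the limit of > 100000 nM in this assay, at which 3 of the 4 values shown sit.

As far as these compounds go, whether that gain is particular to trifluoromethyl remains open, as one real number cannot show a trend. A nitrile or a chloro group on that same aromatic carbon would test how narrow the requirement at this position is.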